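Thiophen-2-yl to Phenyl: What Compound 4 Might Show

A few compounds are considered here, and "the series" means these few. Any claim that something is new, unique, unknown or untested is made for them only; others in the source may bear on it.

Of the compounds shown here, three have so far been measured in a functional assay on SR cells (Homo sapiens) for inhibition, read by sulforhodamine B assay, with a stated time of 48 h; a higher number here means a weaker inhibitor of growth, a lower number a stronger inhibitor of growth. Compound 1 `COc1ccc(-c2cc(-c3cccn3C)c(C#N)c(=O)[nH]2)cc1OC` gives 480 nM, compound 3 `COc1ccc(-c2cc(-c3cccn3C)c(C#N)c(N)n2)cc1OC` gives 56200 nM, and compound 2 `Cn1cccc1-c1cc(-c2cccs2)nc(N)c1C#N` gives 5370 nM. Among these three numbers compound 2 stands second highest: compound 3 is its nearest neighbour, sitting above it by more than the usual scatter, while compound 1 lies furthest away, below it by more than the scatter. Compound 2 is thus a clearly weaker inhibitor of growth than compound 1 and a clearly stronger one than compound 3.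

Compound 4 `Cn1cccc1-c1cc(-c2ccccc2)nc(N)c1C#N` has not been measured yet. It differs from compound 2 in a single place: phenyl in place of thiophen-2-yl on an aromatic carbon. Among the measured compounds shown here, no pair of measured compounds shows this particular exchange, so its effect cannot be read off from the data at hand. Because compound 2 gives 5370 nM and the rest of the molecule is unchanged, the expected step is small, a 1.2-fold higher number from compound 2 to compound 4 (0.08 log units; within the scatter), if anything toward a weaker inhibitor, and it may well stay within the scatter. Compound 4 is therefore estimated at 6500 nM, with a likely range from 2500 nM to 17000 nM.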

Compound 4, concentration for 50% growth inhibition: 35500 nM
Estimate against measurement, compound 4: 5.5-fold (0.74 log units) below; measured number outside the range, above it.
By their numbers in this assay, from the lowest: compound 1; then compound 2; then compounds 4 and 3 (each within the scatter of the next).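

In this assay, phenyl in place of thiophen-2-yl on the aromatic carbon next to the ring nitrogen is not a neutral exchange: the change is a 6.6-fold higher number from compound 2 to compound 4 (0.82 log units; beyond the scatter), so growth inhibition in this series responds to which aromatic ring sits at this position. The ring that enters differs from the one that leaves both in size and in the loss of sulfur, and this single step cannot separate those two differences. Compound 4 now stands within the scatter of compound 3, which differs from it only by two methoxy groups on that phenyl, so on these numbers those groups bring no readable change.

No measurement at hand speaks to the reason for the step from thiophen-2-yl to phenyl. Still open, as far as these compounds go, is how other groups at this position, such as furan-2-yl, a pyridine ring or a simple methyl, would compare, and whether the same exchange would give a step of similar size on the core of compound 1, which carries a carbonyl where compound 3 carries an amino group.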